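This account rests on a few compounds, and the source may have more. Where it says the series, first, only, none or still open, it means among the compounds named here.

Compound 1 `COc1ccc2ncc(S(=O)(=O)c3ccc(Cl)c(Cl)c3)c(N3CCC(C)CC3)c2c1`: 87%
Compound 2 `COc1ccc(S(=O)(=O)c2cnc3cc(F)ccc3c2N2CCC(C)CC2)cc1`: 90%
Compound 3 `COc1ccc(S(=O)(=O)c2cnc3cc(Cl)ccc3c2N2CCC(C)CC2)cc1`: 79%

Three compounds sharing one core were tested in an assay on isolated protein for displacement of a labelled ligand from metabotropic glutamate receptor 5 (Homo sapiens), with a stated time of 60 min, tested at 1 uM; on this read-out higher numbers stand for more inhibition at the one concentration tested (going by the name of the read-out) and lower numbers for less inhibition. Compound 2 gives 90%, the highest of the three numbers; compound 1 gives 87%, which lies within the scatter of compound 2, and compound 3 gives 79%. Within the data shown here, the one single-point step among them, chloro in place of fluoro on an aromatic carbon, gives a number 11 percentage points lower from compound 2 to compound 3 (beyond the scatter).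

Compound 4 `Cc1ccc(S(=O)(=O)c2cnc3cc(F)ccc3c2N2CCC(C)CC2)cc1Cl` has not been measured. It differs from compound 2 in one place: 3-chloro-4-methylphenyl in place of 4-methoxyphenyl on a sulfonyl sulfur. Among the measured compounds shown here, no measured step changes the group on the sulfonyl sulfur alone. Compound 1 also carries chlorine on that group, but it differs from compound 2 in two places, so only its value can be weighed, and that value sits within the scatter of compound 2. For the measured compounds named here, the one known step, from compound 2 to compound 3, touches a different position and was modest. The account therefore expects no step beyond the scatter, or at most a small loss, in this assay. Compound 4 is estimated at 84%, with a range from 68% to 95%, which means an expected step of a number 6 percentage points lower from compound 2 to compound 4 (within the scatter).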

Compound 4, a percentage reported as inhibition, at one concentration (the size of the read-out at that concentration, not a potency): 93%
The estimate for compound 4 lay 9 percentage points below the measured number; the measured number falls inside the stated range.
By their numbers in this assay, from the lowest: compounds 3, 1, 2 and 4 (each within the scatter of the next, the first and the last beyond it).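

In this assay, among these compounds, putting 3-chloro-4-methylphenyl in place of 4-methoxyphenyl on a sulfonyl sulfur gives a number 3 percentage points higher from compound 2 to compound 4 (within the scatter), the first reading of a change to this group alone; the earlier compounds could offer only the value of compound 1, which differs from compound 2 in two places. The entering group has the same number of heavy atoms as the leaving group, but it carries chlorine where the other carries oxygen and lacks its hydrogen-bond acceptor, and at this one concentration that exchange leaves no difference that can be told from the scatter, although a single-concentration reading is not a potency and cannot show whether the two compounds would separate at lower concentrations. Nothing measured here accounts for this outcome.

The compounds shown leave open what the chlorine and the methyl of the new group each contribute on their own, and whether the same change would read alike on the chloro-bearing core of compound 3. Also open, from the compounds shown here alone, is how this position would respond to a group other than a substituted phenyl on the sulfonyl sulfur, such as a pyridine ring, a morpholine or an n-butyl chain.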